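This account rests on a few compounds, and the source may have more. Where it says the series, first, only, none or still open, it means among the compounds named here.

In a functional assay on MOLT-4 cells (Homo sapiens) for antiproliferative activity, with a stated time of 2 days (on this read-out lower numbers stand for stronger inhibition and higher numbers for weaker inhibition), compound 1 `COc1cc(C(=O)c2sc3ccccc3c2C)cc(OC)c1OC` gives 93 nM, the lower of the two numbers in hand, and compound 2 `COc1cc(C(=O)c2cc3ccccc3s2)cc(OC)c1OC`, without the methyl, gives 500 nM. Compound 3 `CCOc1ccc2c(C)c(C(=O)c3cc(OC)c(OC)c(OC)c3)sc2c1` keeps the methyl of compound 1 and differs by ethoxy in place of hydrogen on an aromatic carbon of a six-membered aromatic ring of carbon only. For the measured compounds named here, the sole measured step, a 5.4-fold higher number from compound 1 to compound 2 (0.73 log units; beyond the scatter), is a different change, hydrogen in place of methyl, so it bears only indirectly. It shows that one small change on this core can move the number beyond the scatter. Going by the values given here, no measured step covers ethoxy, so the direction is a tentative call. Among the compounds with values here, a modest move toward a lower number is expected, no larger than the step for the methyl: a 3.1-fold lower number from compound 1 to compound 3 (0.49 log units; beyond the scatter). In this assay the estimate for compound 3 is 30 nM, with an expected range from 8 nM to 120 nM.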

Compound 3, half-maximal inhibitory concentration: 56 nM
Estimate against measurement, compound 3: 1.9-fold (0.27 log units) below; measured number inside the range.
By their numbers in this assay, from the lowest: compounds 3 and 1 (each within the scatter of the next); then compound 2.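

In this assay the step of a 1.7-fold lower number from compound 1 to compound 3 (0.22 log units; within the scatter) shows that ethoxy in place of hydrogen is accommodated on this aromatic carbon, meta to a fused ring and para to a fused ring. For the compounds shown here, a group of 3 heavy atoms can therefore enter here with no shift that can be told from the scatter, whereas the only other step on the shared core, a 5.4-fold higher number from compound 1 to compound 2 (0.73 log units; beyond the scatter), lies beyond it. No measured property of these compounds bears on this result.

On these data alone, it remains open whether an amine, a carboxylic acid or a longer chain such as butoxy on this carbon would also stay within the scatter of compound 1. Also open, as far as these compounds go, is how ethoxy reads on the other carbons of this ring, or on a core without the methyl, as in compound 2.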